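The source may hold more compounds than are shown below. What is called first, only, known or untested is meant among the compounds shown, and "the series" means these compounds.

Compound 1, `COc1cc(C(=O)c2sc3ccccc3c2-c2ccc(C)cc2)cc(OC)c1OC`, compound 2, `CCOc1ccc(-c2c(C(=O)c3cc(OC)c(OC)c(OC)c3)sc3ccccc23)cc1`, and compound 3, `COc1cc(C(=O)c2sc3cc(C)ccc3c2Nc2ccc(C)cc2)cc(OC)c1OC`, share a trimethoxyphenyl ketone on a sulfur-containing bicyclic core and were tested in a functional assay on A549 cells (Homo sapiens) for antiproliferative activity, read by MTT assay, with a stated time of 72 h; on this read-out higher numbers stand for weaker inhibition and lower numbers for stronger inhibition. In this assay compound 1 gives 7800 nM and compound 2 gives 3100 nM. Among the measured compounds shown here, the single change between them, (ethoxy in place of methyl on an aromatic carbon), brings a 2.5-fold lower number from compound 1 to compound 2 (0.40 log units; beyond the scatter). Compound 3 gives 1900 nM; it carries a further methyl on its core and joins its outer ring through a nitrogen, so the difference between its core and the core of compound 1 is not broken down here. Compound 3 and compound 2 lie within the usual scatter of each other, so no order between them can be read.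

Compound 4, `CCOc1ccc(Nc2c(C(=O)c3cc(OC)c(OC)c(OC)c3)sc3cc(C)ccc23)cc1`, has not yet been measured. It differs from compound 3 by ethoxy in place of methyl on an aromatic carbon, the same change that turns compound 1 into compound 2, made at a place described in the same words. For the measured compounds named here, on that basis a lower number is expected for compound 4, of roughly the size seen from compound 1 to compound 2, because a 2.5-fold lower number from compound 1 to compound 2 (0.40 log units; beyond the scatter) is the only guide available; the estimated step is a 2.1-fold lower number from compound 3 to compound 4 (0.32 log units; beyond the scatter). Since the core of compound 3 is not the core of compound 1, the carry-over is uncertain, and the expected range is kept wide. Compound 4 is estimated at 900 nM, between 350 nM and 2500 nM.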

Compound 4, half-maximal inhibitory concentration: 5800 nM
Compound 4: middle estimate off by 6.4-fold (0.81 log units), on the low side, outside the stated range (above it).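

In this assay, the core that carries the further methyl and the nitrogen link responds to ethoxy in place of methyl with a 3.1-fold higher number from compound 3 to compound 4 (0.48 log units; beyond the scatter), so the change that helped on the first core goes the other way here. Among the compounds shown here, the two steps therefore do not agree, and the gap between them is larger than repeated measurements would explain: the same change on two cores in this assay, a 2.5-fold lower number (0.40 log units; beyond the scatter) from compound 1 to compound 2 and a 3.1-fold higher number (0.48 log units; beyond the scatter) from compound 3 to compound 4, 7.7-fold (0.89 log units) apart, beyond the scatter of two such steps This shows that, in this series, a step measured on one core is not a safe guide to the same change on the other, but it rests on only two pairs of compounds and does not show why the direction reverses, or which of the two core differences goes with the reversal.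

The compounds shown leave open whether the nitrogen link alone or the further core methyl alone is enough to reverse the step, since both differences appear together and no pair here separates them. They also leave open how other groups in place of the methyl would behave on each core, such as a longer chain like propoxy, an amine or a carboxylic acid.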